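The source may report more compounds than this note shows. Statements on the series, on what has been measured and on what is new or still open speak of the compounds shown alone.

Measured in a functional assay on SW-620 cells (Homo sapiens) for inhibition, read by MTT assay, with a stated time of 72 h; on this read-out lower numbers stand for stronger inhibition and higher numbers for weaker inhibition:

- compound 1 `COc1cc(Oc2cccc(Nc3ccccc3)c2)cc(OC)c1CNCc1ccc(F)cc1`: 6770 nM
- compound 2 `COc1cc(Oc2cccc(Nc3ccccc3)c2)cc(OC)c1CNCCNC(C)=O`: 11900 nM
- compound 3 `COc1cc(Oc2cccc(Nc3ccccc3)c2)cc(OC)c1CN(C)C`: > 20000 nM (a limit of the assay, not a number)

Compound 2 and compound 1 sit within the scatter of each other, as a 1.8-fold higher number from compound 1 to compound 2 (0.24 log units; within the scatter) shows. Compound 3 has no exact number, only the limit > 20000 nM.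

The next compound to be tested in this assay is compound 4 `COc1cc(Oc2cccc(Nc3ccccc3)c2)cc(OC)c1CCO`. Compared with compound 2, it has hydroxymethyl in place of (2-acetamidoethyl)amino on a saturated chain carbon bound to an aromatic carbon.

For the measured compounds named here, no measured compound carries hydroxymethyl at this place, so the nearest guides are the other changes made there. One is an at least 1.6-fold higher number from compound 2 to compound 3 (0.22 log units; that floor lies within the scatter), whose floor lies within the scatter. The other is an at least 2.9-fold higher number from compound 1 to compound 3 (0.47 log units; beyond the scatter), which goes beyond the scatter. Going by these compounds, both point towards higher numbers, and both end at a limit, so their true sizes remain unknown.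

A modest move to a higher number is therefore expected, and the measurement may return only a limit. The expected change is a 1.6-fold higher number from compound 2 to compound 4 (0.20 log units; within the scatter). For compound 4, the estimated value is 19000 nM, with an expected range of 9000 nM to 40000 nM.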

Compound 4, half-maximal inhibitory concentration: > 20000 nM
Compound 4 gave a limit, no number; the forecaster's own chance of this, stated with the estimate: 45%; at least 1.0-fold (0.02 log units) between middle value and limit.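

In this assay compound 4 gives > 20000 nM, which is a limit of the assay and not a number. Compound 4 is the first compound shown with no amine nitrogen at this place, and hydroxymethyl in place of (4-fluorobenzyl)amino gives an at least 2.9-fold higher number from compound 1 to compound 4 (0.47 log units; beyond the scatter), while hydroxymethyl in place of (2-acetamidoethyl)amino gives an at least 1.6-fold higher number from compound 2 to compound 4 (0.22 log units; that floor lies within the scatter), so only the first of these steps is certain to exceed the scatter. The step between compound 3 and compound 4 cannot be read, and the other two sizes remain floors, because the measurements stop at the same limit: the limit of > 20000 nM in this assay, at which 2 of the 4 values shown sit.

The compounds shown cannot separate the loss of the amine from the loss of the larger side chain, since compound 3 keeps an amine and also ends at the limit, so amine nitrogen alone does not give a measurable number here. Still open, going by these compounds, is whether a piperazine, a carboxylic acid or a longer chain ending in a 4-fluorophenyl ring at this place would give a number, and how such a number would compare with those of compound 1 and compound 2.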